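Fluorine and amide reversal on the pyrazole carboxamide series

The compounds below may be only part of what the source reports. "The series", "measured", "known", "first", "only" and "open" are said of these compounds alone.

Compound 1 `Cc1cc(C(=O)Nc2ccc(F)cc2)nn1Cc1cc(Cl)ccc1OCc1ccccc1`: 3
Compound 2 `Cc1cc(C(=O)Nc2ccccn2)nn1Cc1cc(Cl)ccc1OCc1ccccc1`: > 3.7
Compound 3 `Cc1cc(NC(=O)C2CCOC2)nn1Cc1cc(Cl)ccc1OCc1ccccc1`: > 3.7

Among the compounds with values here, measured in a physicochemical assay for lipophilicity, at pH 7.4 (on this read-out higher numbers stand for higher lipophilicity and lower numbers for lower lipophilicity), compound 1 gives 3, the only plain number among the three. Compound 2 reaches a limit of the assay, > 3.7. Compound 3 likewise reaches a limit, > 3.7. Both steps from compound 1 exceed the scatter: a number at least 0.70 log units higher from compound 1 to compound 2 (beyond the scatter) and a number at least 0.70 log units higher from compound 1 to compound 3 (beyond the scatter), whereas a step that the two limits leave unreadable from compound 2 to compound 3.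

Compound 4 `Cc1cc(NC(=O)c2c(F)cccc2F)nn1Cc1cc(Cl)ccc1OCc1ccccc1` differs from compound 1 by ((2,6-difluorophenyl)carbonyl)amino in place of (4-fluorophenyl)carbamoyl on an aromatic carbon. Neither measured step bears directly on this change, which keeps an aromatic amide and adds one fluorine. Compound 4 is therefore expected to sit close to compound 1, perhaps slightly higher, giving a number 0.30 log units higher from compound 1 to compound 4 (within the scatter). The estimate for compound 4 is 3.3, between 2.8 and 3.8.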

Compound 4, distribution coefficient: > 3.7
Compound 4 ended at the assay's limit; the forecaster's own chance of this, stated with the estimate: 20%; at least 0.40 log units between middle value and limit.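

In this assay compound 4 gives > 3.7, which is a limit of the assay and not a number. Putting ((2,6-difluorophenyl)carbonyl)amino in place of (4-fluorophenyl)carbamoyl at this position gives a number at least 0.70 log units higher from compound 1 to compound 4 (beyond the scatter), so an aromatic group on the carbonyl carbon reaches the limit here, as oxolan-3-yl does in compound 3. The steps from compound 2 and compound 3 to compound 4 cannot be read: the limit of > 3.7 in this assay, at which 3 of the 4 values shown sit.

Going by these compounds, how far apart these three compounds lie remains open. Also open, on these data alone, is whether an amine or a carboxylic acid in place of 2,6-difluorophenyl would bring the value back within the assay's range.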